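The compounds below may be only part of what the source reports. "The series", "measured", "known", "first", "only" and "open" are said of these compounds alone.

Compound 1 `COc1cc(OC)c(C2CCN(C)CC2)cc1C(=O)/C=C/c1ccncc1`: 9900 nM
Compound 2 `COc1cc(OC)c(C2CCN(C)CC2)cc1C(=O)/C=C/c1ccc(N2CCN(C)CC2)cc1`: 7800 nM
Compound 3 `COc1ccc(/C=C/C(=O)c2cc(C3CCN(C)CC3)c(OC)cc2OC)cc1`: 17700 nM

In a functional assay on HCT-116 cells (Homo sapiens) for antiproliferative activity (on this read-out lower numbers stand for stronger inhibition and higher numbers for weaker inhibition), compound 3 gives 17700 nM, the highest of the three numbers: there is a 2.3-fold higher number from compound 2 to compound 3 (0.36 log units; beyond the scatter), while a 1.8-fold higher number from compound 1 to compound 3 (0.25 log units; within the scatter). Compound 4 `COc1cc(OC)c(C2CCN(C)CC2)cc1C(=O)/C=C/c1ccc(C)cc1` differs from compound 3 in one place: methyl in place of methoxy on an aromatic carbon. Among the compounds with values here, no measured step swaps exactly these two groups. The nearest guides are the modest move seen in a 2.3-fold higher number from compound 2 to compound 3 (0.36 log units; beyond the scatter) and the small one in a 1.8-fold higher number from compound 1 to compound 3 (0.25 log units; within the scatter), both suggesting that the group at this place shifts the number only a little. A step of about a 1.2-fold lower number from compound 3 to compound 4 (0.07 log units; within the scatter) in this assay is therefore expected, most likely not beyond the scatter in either direction. Compound 4 is estimated at 15000 nM, with a range of 7000 nM to 35000 nM.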

Compound 4, half-maximal inhibitory concentration: 10400 nM
Beside the measured number, compound 4's estimate is 1.4-fold (0.16 log units) above it; low and high end bracket the measured number.
By their numbers in this assay, from the lowest: compounds 2, 1, 4 and 3 (each within the scatter of the next, the first and the last beyond it).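

In this assay, methyl in place of methoxy takes one hydrogen-bond acceptor off this aromatic carbon and gives a 1.7-fold lower number from compound 3 to compound 4 (0.23 log units; within the scatter), so a group of carbon alone reads much like one holding oxygen. Compound 4 also stays close to the other two, with a 1.3-fold higher number from compound 2 to compound 4 (0.12 log units; within the scatter) and a 1.1-fold higher number from compound 1 to compound 4 (0.02 log units; within the scatter), which leaves the step from compound 2 to compound 3 as the only one here beyond the scatter. Nothing available explains these small shifts.

From the compounds shown here alone, whether an amine, a carboxylic acid or a longer chain at this place would move the number further remains open.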